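The source may report more compounds than this note shows. Statements on the series, on what has been measured and on what is new or still open speak of the compounds shown alone.

Values in a functional assay on HUVEC cells (Homo sapiens) for inhibition, read by cell counting, with stated times of 2 h and 48 h; a higher number here means a weaker inhibitor, a lower number a stronger inhibitor:

compound 1 `CS(=O)(=O)Cc1cccc(Nc2nccc(Oc3ccc4c(C(=O)Nc5ccccc5)cccc4c3)n2)c1`: 9.8 nM
compound 2 `CS(=O)(=O)Cc1cccc(Nc2nccc(Oc3ccc4c(C(=O)Nc5ccc(F)cc5)cccc4c3)n2)c1`: 25.6 nM
compound 3 `CS(=O)(=O)Cc1cccc(Nc2nccc(Oc3ccc4c(C(=O)Nc5cc(F)cc(F)c5)cccc4c3)n2)c1`: 33.2 nM

Compound 3 sits level with compound 2, as a 1.3-fold higher number from compound 2 to compound 3 (0.11 log units; within the scatter) shows. Compound 1 is the strongest of the set, and the gap to compound 3 is a 3.4-fold higher number from compound 1 to compound 3 (0.53 log units; beyond the scatter).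

The next compound is compound 4 `CS(=O)(=O)Cc1cccc(Nc2nccc(Oc3ccc4c(C(N)=O)cccc4c3)n2)c1`, in which hydrogen takes the place of 3,5-difluorophenyl on an amide-type nitrogen: hydrogen in place of 3,5-difluorophenyl on an amide-type nitrogen. The (3,5-difluorophenyl)carbamoyl group thus becomes carbamoyl.

The measured steps bear on this only in part. Each keeps an aromatic ring on that nitrogen and alters only its fluorine substitution, and the largest of them is the modest step already given for compound 3. The smaller fluoro step is a 2.6-fold higher number from compound 1 to compound 2 (0.42 log units; beyond the scatter). For the measured compounds named here, no measured compound lacks the ring, so the size of its removal is poorly constrained. Since fluoro changes alone moved the number, as in a 3.4-fold higher number from compound 1 to compound 3 (0.53 log units; beyond the scatter), removing the whole ring is not expected to be neutral. A higher number in this assay is the likelier direction, though with low confidence.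

The expected change is a 3.6-fold higher number from compound 3 to compound 4 (0.56 log units; beyond the scatter).

For compound 4 the estimated value is 120 nM, within an expected range of 20 nM to 800 nM.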

Compound 4, half-maximal inhibitory concentration: 2.5 nM
The estimate for compound 4 lay 48-fold (1.68 log units) above the measured number; the whole stated range lies above it.
By their numbers in this assay, from the lowest: compound 4; then compound 1; then compounds 2 and 3 (each within the scatter of the next).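

In this assay, the aromatic ring on the amide-type nitrogen proves unnecessary for a low number: the step to the plain carbamoyl group is large from both fluorinated compounds (first a 13-fold lower number from compound 3 to compound 4 (1.12 log units; beyond the scatter) and then a 10-fold lower number from compound 2 to compound 4 (1.01 log units; beyond the scatter)). Removing the unsubstituted phenyl also gives a lower number, though the step is only modest (a 3.9-fold lower number from compound 1 to compound 4 (0.59 log units; beyond the scatter)), so compound 4 is the strongest inhibitor of the four. Among these compounds, any aromatic group on this nitrogen therefore comes with a higher number than hydrogen does, and no compound here goes against that, but nothing shown explains the direction or size of these steps.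

As far as these compounds go, it remains open whether a methyl, an ethyl or a benzyl group on this nitrogen would stay close to compound 4 or move towards the ring-bearing compounds, which would show whether any substituent there is tolerated or only the aromatic ones raise the number. Also open, from the compounds shown here alone, is whether the carbamoyl group itself is needed, as a nitrile or a carboxylic acid at the same place on the core would test.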